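A Smaller Terminal Group on the Shared Core

The compounds below may be only part of what the source reports. "The series", "measured", "known", "first", "only" and "open" are said of these compounds alone.

The compounds share a common core, carried by compound 1 `CC[C@H](C)[C@H](NC(=O)c1cccc(Cn2ccnc2)c1)C(=O)NNS(=O)(=O)c1ccccc1` and compound 2 `CC[C@H](C)[C@H](NC(=O)c1cccc(Cn2ccnc2)c1)C(=O)NS(=O)(=O)c1ccccc1`, which differ only at the amide-type nitrogen. In an assay on HEK293 cells for displacement of a labelled ligand from Type-2 angiotensin II receptor (Homo sapiens), tested at 10 uM (on this read-out higher numbers stand for a stronger effect at the one concentration tested and lower numbers for a weaker effect), compound 1 gives 18%, and compound 2 gives 24%; the step of a number 6 percentage points higher from compound 1 to compound 2 (within the scatter) lies within the scatter, so these two show no difference worth speaking of. Compound 3 `CCCCCS(=O)(=O)NNC(=O)[C@@H](NC(=O)c1cccc(Cn2ccnc2)c1)[C@@H](C)CC` carries a (pentylsulfonyl)amino group on the amide-type nitrogen, but in this assay compound 3 gives "not determined" (no result reported), so it stands nowhere on the numbers shown. Compound 4 `CC[C@H](C)[C@H](NC(=O)c1cccc(Cn2ccnc2)c1)C(=O)NO` is compound 3 with the change (hydroxy in place of (pentylsulfonyl)amino on an amide-type nitrogen). Going by the values given here, no measured step covers this change: the one known step, a number 6 percentage points higher from compound 1 to compound 2 (within the scatter), swaps a (phenylsulfonyl)amino group for phenylsulfonyl and stays within the scatter, and it says nothing about a hydroxy group on the amide-type nitrogen. The two measured values both sit at a low level, and nothing in the data gives a reason for compound 4 to move far from that level, in either direction, beyond the scatter. Compound 4 is therefore expected to give about 20% in this assay, with a range from 0% to 45%.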

Compound 4, a percentage reported as inhibition, at one concentration (the size of the read-out at that concentration, not a potency): 4%
For compound 4 the middle estimate is 16 percentage points above the measured one; measured number inside the range.
By their numbers in this assay, from the lowest: compound 4; then compounds 1 and 2 (each within the scatter of the next).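

At the amide-type nitrogen, hydroxy is the first replacement shown to move the read-out beyond the scatter in this assay: in place of phenylsulfonyl it gives a number 20 percentage points lower from compound 2 to compound 4 (beyond the scatter), and in place of (phenylsulfonyl)amino it gives a number 14 percentage points lower from compound 1 to compound 4 (beyond the scatter). The earlier step, a number 6 percentage points higher from compound 1 to compound 2 (within the scatter), could not show that this position responds to what it carries, whereas these two steps show a modest response when the sulfonyl-bearing groups give way to hydroxy, the smallest group shown here. Nothing available accounts for this change in the read-out.

Steps to or from compound 3 cannot be read, so the compounds shown leave open whether its (pentylsulfonyl)amino group would sit with the phenylsulfonyl-bearing compounds or nearer to compound 4. They also leave open where a methoxy group, a plain amino group or a longer alkyl chain on the same nitrogen would fall relative to hydroxy and the sulfonyl-bearing groups.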